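Swapping an aryl amide for a benzyl amide on a hydroxylamine-bearing core

This account rests on a few compounds, and the source may have more. Where it says the series, first, only, none or still open, it means among the compounds named here.

Measured so far:
- compound 1 `COc1ccc(-c2cc(NO)c(C(=O)Nc3ccccc3)c(=O)o2)cc1`: 16200 nM
- compound 2 `COc1ccc(NC(=O)c2c(NO)cc(-c3ccccc3)oc2=O)cc1`: > 20000 nM
- compound 3 `COC(=O)c1ccc(NC(=O)c2c(NO)cc(-c3ccccc3)oc2=O)cc1`: > 20000 nM

In an ADME assay on Huh-7 cells (Homo sapiens) for cytotoxicity, read by a luciferase reporter and WST assay, with a stated time of 3 days (a higher number here means that more compound is tolerated, a lower number that less compound is tolerated), compound 1 gives 16200 nM. Compound 2 reaches only the limit of this assay, > 20000 nM, which is not a measured number. Compound 3 likewise stops at the limit, > 20000 nM. So compound 2 stands at the upper edge of what this assay can read, with no number of its own, and the limit of > 20000 nM in this assay, at which 2 of the 3 values shown sit, shows that it shares this position with compound 3.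

Within the data shown here, the one measured step, a step that the two limits leave unreadable from compound 2 to compound 3, cannot be sized, since both ends are limits. Compound 4 `O=C(NCc1ccccc1)c1c(NO)cc(-c2ccccc2)oc1=O` differs from compound 2 by benzyl in place of 4-methoxyphenyl on an amide-type nitrogen. Among the measured compounds shown here, no measured step involves a change on the amide nitrogen, so there is nothing to point to a direction, and the only readable value, that of compound 1, lies within the same region.

The step of a number no higher from compound 2 to compound 4 (the limit leaves the size open) is therefore expected to be small, and compound 4 is estimated at 20000 nM, within 9000 nM to 45000 nM.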

Compound 4, half-maximal cytotoxic concentration: > 20000 nM
Compound 4: a limit, no number (the forecaster's own chance of this, stated with the estimate: 60%); the middle value lies on the limit itself.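

Compound 2 and compound 4 both stop at a limit rather than a number, so the step between them cannot be read: the limit of > 20000 nM in this assay, at which 3 of the 4 values shown sit.

The compounds shown leave open whether benzyl in place of 4-methoxyphenyl on the amide-type nitrogen changes how much compound is tolerated in this assay.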